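Swapping a trichlorophenyl for a dimethoxyphenyl in weak inhibitors

A few compounds are considered here, and "the series" means these few. Any claim that something is new, unique, unknown or untested is made for them only; others in the source may bear on it.

Compound 1 `CN(C)C/C=C/C(=O)Nc1cccc(S(=O)(=O)N2CCC(NC(=O)c3n[nH]cc3NC(=O)c3c(Cl)cc(Cl)cc3Cl)CC2)c1`: >= 500 nM
Compound 2 `CCC(=O)Nc1cccc(S(=O)(=O)N2CCC(NC(=O)c3n[nH]cc3NC(=O)c3c(Cl)cccc3Cl)CC2)c1`: > 1000 nM
Compound 3 `CN(C)CC/C=C/C(=O)Nc1cccc(N2CCC(NC(=O)c3n[nH]cc3NC(=O)c3c(Cl)cccc3Cl)CC2)c1`: 1000 nM

Of the compounds shown here, three share a core and have been tested in an assay on HEK293 cells for inhibition of cyclin-dependent kinase 14 (Homo sapiens), with a stated time of 4 h; a higher number here means a weaker inhibitor, a lower number a stronger inhibitor. Compound 1 gives >= 500 nM, which is a limit of the assay rather than a number, (the limit of >= 500 nM in this assay, at which 1 of the 3 values shown sits). Compound 2 gives > 1000 nM, also a limit of the assay and not a number, (the limit of > 1000 nM in this assay, at which 1 of the 3 values shown sits). Compound 3 gives 1000 nM. With two limits and one value, compound 1 cannot be ranked against the others; all that can be said is that none of the three shows strong inhibition.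

Compound 4 `COc1cccc(OC)c1C(=O)Nc1c[nH]nc1C(=O)NC1CCN(S(=O)(=O)c2cccc(NC(=O)/C=C/CN(C)C)c2)CC1` differs from compound 1 in one place: 2,6-dimethoxyphenyl in place of 2,4,6-trichlorophenyl on a carbonyl carbon. Within the data shown here, no measured pair shows what this kind of change does here, so there is no measured step to lean on. Since compound 1 itself sits at a limit, the step from compound 1 to compound 4 is expected to be small, with no clear direction beyond the scatter, as a step that the limit leaves unreadable from compound 1 to compound 4 expresses. Compound 4 is therefore expected to give about 1500 nM, in a range from 300 nM to 8000 nM.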

Compound 4, half-maximal inhibitory concentration: > 1000 nM
Compound 4: a limit, no number; the forecaster's own chance of this, stated with the estimate: 55%; the middle value does not contradict the limit.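

In this assay compound 1 gives >= 500 nM, which is a limit and not a number. Compound 4 gives > 1000 nM, also a limit, and no step can be read between these two compounds. As far as these compounds go, whether 2,6-dimethoxyphenyl in place of 2,4,6-trichlorophenyl strengthens or weakens inhibition remains open.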